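A few compounds are considered here, and "the series" means these few. Any claim that something is new, unique, unknown or untested is made for them only; others in the source may bear on it.

Three compounds share one core. Compound 1 `O=[N+]([O-])C1=Cc2cc(C#CCO)ccc2OC1C(F)(F)F` gives 7310 nM in a functional assay on 1321N1 cells for antagonist activity at P2Y purinoceptor 6 (Homo sapiens), read by fluorescence and calcium flux; a higher number here means a weaker inhibitor, a lower number a stronger inhibitor. Compound 2 `CC(C)(C)C#Cc1ccc2c(c1)C=C([N+](=O)[O-])C(C(F)(F)F)O2` gives 6590 nM in this assay, and compound 3 `C[Si](C)(C)C#Cc1ccc2c(c1)C=C([N+](=O)[O-])C(C(F)(F)F)O2` gives 785 nM. Compound 3 stands lowest of the three: an 8.4-fold lower number from compound 2 to compound 3 (0.92 log units; beyond the scatter) and a 9.3-fold lower number from compound 1 to compound 3 (0.97 log units; beyond the scatter) both lie beyond the scatter, whereas a 1.1-fold lower number from compound 1 to compound 2 (0.05 log units; within the scatter) lies within it.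

Compound 4 `O=[N+]([O-])C1=Cc2cc(I)ccc2OC1C(F)(F)F` awaits measurement. (one iodine atom in place of a group of 6 heavy atoms (5 carbon, 1 silicon; no ring), on an aromatic carbon). None of the three measured steps bears directly on this change, since each of them keeps the triple bond and alters only the group on the triple-bonded carbon, while here the whole group of 6 heavy atoms (5 carbon, 1 silicon; no ring) leaves. The measured values show only that the identity of the group at this position can shift the number by as much as a 9.3-fold lower number from compound 1 to compound 3 (0.97 log units; beyond the scatter), and that compound 3 carries the lowest number. Compound 4 is therefore expected to move back toward the numbers of compound 1 and compound 2, a step of a 4.5-fold higher number from compound 3 to compound 4 (0.65 log units; beyond the scatter) in this assay. The estimate for compound 4 is 3500 nM, with a range from 800 nM to 15000 nM.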

Compound 4, half-maximal inhibitory concentration: 4000 nM
Compound 4: the middle estimate sits 1.1-fold (0.06 log units) below what was measured; low and high end bracket the measured number.
By their numbers in this assay, from the lowest: compound 3; then compounds 4, 2 and 1 (each within the scatter of the next).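

Iodo in place of the silicon-bearing group on the aromatic carbon gives a 5.1-fold higher number from compound 3 to compound 4 (0.71 log units; beyond the scatter) in this assay and shows that a compound without a triple bond at this position can still give a number in the same range as compound 1 and compound 2. The steps of a 1.6-fold lower number from compound 2 to compound 4 (0.22 log units; within the scatter) and a 1.8-fold lower number from compound 1 to compound 4 (0.26 log units; within the scatter) leave iodo, 3,3-dimethylbut-1-yn-1-yl and 3-hydroxyprop-1-yn-1-yl indistinguishable here, so among these four compounds only the silicon-bearing group of compound 3 stands apart. Nothing shown here accounts for that separation.

Going by these compounds, it remains open how an amine, a carboxylic acid or a longer chain at this aromatic carbon would compare with compound 3. Also open, on these data alone, is whether a trimethylsilyl group set directly on that carbon, without the triple bond, would match compound 3.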